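The source may hold more compounds than are shown below. What is called first, only, known or untested is meant among the compounds shown, and "the series" means these compounds.

Measured so far:
compound 1 `C=CCNC(=O)/C(C)=C(\C)c1ccc(Br)cc1` — 120 mg/kg in a toxicity assay on the whole organism (strain Icem-CET (SPF Caw)) for cytotoxicity, with Mus musculus as the target; on this read-out lower numbers stand for an effect already at smaller amounts and higher numbers for an effect only at larger amounts of compound
compound 2 `C#CCNC(=O)/C(C)=C(\C)c1ccc(C)cc1` — 120 mg/kg in this assay
compound 3 `C=CCNC(=O)/C(C)=C(\C)c1ccc(C)cc1` — not yet measured

In this assay compound 2 gives 120 mg/kg and stands level with compound 1, which gives 120 mg/kg; the two values are within the scatter. Compound 3 carries vinyl in place of ethynyl on a saturated chain carbon bound to an amide-type nitrogen. For the measured compounds named here, no measured pair shows this step on its own. Compound 1 already bears the allyl chain and sits level with compound 2, so no shift beyond the scatter is expected from this assay here. Compound 3 is estimated at 120 mg/kg, expected between 70 mg/kg and 200 mg/kg, a step of no change at the digits printed from compound 2 to compound 3 (within the scatter) that is expected to lie within the scatter.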

Compound 3, dose for half-maximal effect: 100 mg/kg
For compound 3 the middle estimate is 1.2-fold (0.08 log units) above the measured one; measured number inside the range.
By their numbers in this assay, from the lowest: compounds 3, 1 and 2 (each within the scatter of the next).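

In this assay, the exchange of propargyl for allyl on a saturated chain carbon bound to an amide-type nitrogen can now be read on its own: a 1.2-fold lower number from compound 2 to compound 3 (0.08 log units; within the scatter). At the aromatic carbon, methyl in place of bromo gives a 1.2-fold lower number from compound 1 to compound 3 (0.08 log units; within the scatter), so neither single change moves the read-out beyond the scatter. Nothing measured here bears on why these steps are this size.

Open, as far as these compounds go, is how a longer chain or an amine at the chain position would read in this assay. Also open, from the compounds shown here alone, is how a carboxylic acid or a nitrile on the aromatic carbon would read.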